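The source may report more compounds than this note shows. Statements on the series, on what has been measured and on what is new or still open speak of the compounds shown alone.

Compound 1 `Cc1n[nH]c(C(=O)O)c1Cc1cccc(-c2ccc(C(N)=O)cc2)c1` and compound 2 `Cc1n[nH]c(C(=O)O)c1Cc1cc2ccccc2o1` share the same core and were both tested in an assay on isolated protein for inhibition of 2-Hydroxyacid oxidase 2 (Homo sapiens), tested at 10 uM; a lower number here means a weaker effect, a higher number a stronger effect of the compound at the concentration tested. In this assay compound 1 gives 60%, and compound 2 gives 66%. Compound 1 carries the lower of the two numbers, yet the gap to compound 2 is within the usual scatter, so the two cannot be ranked against each other.

Compound 3 `Cc1n[nH]c(C(=O)O)c1Cc1cccc(-c2ccc(C(=O)O)cc2)c1` differs from compound 1 in a single place: hydroxy in place of amino on a carbonyl carbon. For the measured compounds named here, no pair of measured compounds in this set shows that change, so its effect in this assay has to be estimated from compound 1 alone. The step expected from this change is no change at the digits printed from compound 1 to compound 3 (within the scatter), a shift that is not expected to go beyond the scatter in either direction. Compound 3 is therefore expected to give about 60%, with a range from 35% to 82%.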

Compound 3, a percentage reported as inhibition, at one concentration (the size of the read-out at that concentration, not a potency): 15%
Compound 3: middle estimate off by 45 percentage points, on the high side; the whole stated range lies above it.
By their numbers in this assay, from the lowest: compound 3; then compounds 1 and 2 (each within the scatter of the next).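

For the compounds shown here, the change from carbamoyl to carboxy gives the first single-place step in this set, and in this assay it brings a number 45 percentage points lower from compound 1 to compound 3 (beyond the scatter). This position is therefore sensitive to what sits on the carbonyl carbon: exchanging one heavy atom, amino for hydroxy, is enough to move the read-out beyond the scatter, even though the computed counts for the two groups match. No measurement available here explains this drop.

The compounds shown do not settle whether the amino group favours the effect or the hydroxy group works against it; a methyl ester or a nitrile at this place would help separate those two readings. Going by these compounds alone, with only one pair, it also remains open whether the same change would act alike elsewhere on the shared core.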